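Replacing 1-methylhexyl with (thiophen-2-yl)methyl on the shared core

The source may report more compounds than this note shows. Statements on the series, on what has been measured and on what is new or still open speak of the compounds shown alone.

Of the compounds shown here, three with a shared core have been measured in a functional assay on K562 cells (Homo sapiens) for antiproliferative activity, read by CellTiter-Glo, with a stated time of 72 h; on this read-out lower numbers stand for an effect already at smaller amounts and higher numbers for an effect only at larger amounts of compound. There, compound 1 `CCCCCNc1ncnc2c1ncn2[C@@H]1O[C@H](COS(N)(=O)=O)[C@@H](O)[C@H]1O` gives 181 nM, compound 2 `CCCCCCCNc1ncnc2c1ncn2[C@@H]1O[C@H](COS(N)(=O)=O)[C@@H](O)[C@H]1O` gives 132 nM and compound 3 `CCCCCC(C)Nc1ncnc2c1ncn2[C@@H]1O[C@H](COS(N)(=O)=O)[C@@H](O)[C@H]1O` gives 203 nM. Compound 3 therefore stands level with the other two: a 1.1-fold higher number from compound 1 to compound 3 (0.05 log units; within the scatter) and a 1.5-fold higher number from compound 2 to compound 3 (0.19 log units; within the scatter) are both within the scatter, as is a 1.4-fold lower number from compound 1 to compound 2 (0.14 log units; within the scatter).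

Compound 4 `NS(=O)(=O)OC[C@H]1O[C@@H](n2cnc3c(NCc4cccs4)ncnc32)[C@H](O)[C@@H]1O` differs from compound 3 in one group: (thiophen-2-yl)methyl in place of 1-methylhexyl on a nitrogen on an aromatic ring. Thus (thiophen-2-yl)methyl stands in place of 1-methylhexyl on a nitrogen on an aromatic ring. The three measured steps all exchange one open chain for another at this place, so they bear on the new change only indirectly, and none of them involves a ring. Their small size gives no reason to expect a clear move in either direction in this assay, although the uncertainty is wide. The expected change is a 1.1-fold lower number from compound 3 to compound 4 (0.05 log units; within the scatter), which is no step beyond the scatter. For compound 4 the estimated value is 180 nM, with an expected range from 60 nM to 550 nM.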

Compound 4, half-maximal effective concentration: 114 nM
Compound 4: the middle estimate sits 1.6-fold (0.20 log units) above what was measured; measured number inside the range.
By their numbers in this assay, from the lowest: compounds 4, 2, 1 and 3 (each within the scatter of the next).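

In this assay, among these compounds, the place on a nitrogen on an aromatic ring now carries a ring for the first time, and (thiophen-2-yl)methyl stands level with all three open chains (a 1.8-fold lower number from compound 3 to compound 4 (0.25 log units; within the scatter)) (a 1.2-fold lower number from compound 2 to compound 4 (0.06 log units; within the scatter)) (a 1.6-fold lower number from compound 1 to compound 4 (0.20 log units; within the scatter)). Among the four compounds, then, this place takes a five-membered aromatic ring with a sulfur atom and one hydrogen-bond acceptor, in place of a purely carbon chain, with no step beyond the scatter. No measured evidence is available that would account for this result.

The compounds shown leave open whether benzyl, or a chain carrying an amine or a carboxylic acid, would stay level on this nitrogen. They also leave open whether thiophen-3-yl would behave as thiophen-2-yl does here.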